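Ethyl added to the benzoyl ring of compound 2

This account rests on a few compounds, and the source may have more. Where it says the series, first, only, none or still open, it means among the compounds named here.

Measured compounds:
compound 1, `COc1ccccc1C(=O)N(NC(=O)c1ccccc1)C(C)(C)C`: 525 nM
compound 2, `CC(C)(C)N(NC(=O)c1ccccc1)C(=O)C1CCCCC1`: 46800 nM

Both compounds were tested in an assay on cells for agonist activity at ecdysone receptor (Bombyx mori), read by a luciferase reporter, with a stated time of 24 h; on this read-out higher numbers stand for an effect only at larger amounts of compound and lower numbers for an effect already at smaller amounts. Compound 1 gives 525 nM. Among the measured compounds shown here, compound 2 gives 46800 nM, the highest of the two numbers; the only neighbour is compound 1, and the difference between them is an 89-fold higher number from compound 1 to compound 2 (1.95 log units; beyond the scatter). That step swaps the group on one carbonyl carbon, cyclohexyl in place of 2-methoxyphenyl, and is well beyond the scatter.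

Compound 3, `CCc1ccc(C(=O)NN(C(=O)C2CCCCC2)C(C)(C)C)cc1`, keeps the cyclohexyl of compound 2 and changes the other side: ethyl in place of hydrogen on an aromatic carbon, placed on an aromatic carbon of a six-membered aromatic ring of carbon only, para to a large group. Cut one bond further out, this reads phenyl to 4-ethylphenyl.

For the measured compounds named here, no measured step touches this ring, so the only known step, the large one from compound 1 to compound 2, does not bear on it. With nothing to go on, the expected step in this assay is a 1.9-fold lower number from compound 2 to compound 3 (0.27 log units; within the scatter), which lies within the scatter. Compound 3 is therefore expected to give about 25000 nM, somewhere between 6000 nM and 100000 nM.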

Compound 3, half-maximal effective concentration: 9330 nM
The estimate for compound 3 lay 2.7-fold (0.43 log units) above the measured number; measured number inside the range.
By their numbers in this assay, from the lowest: compound 1; then compound 3; then compound 2.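

Compound 1 and compound 2 differ only at the other carbonyl carbon, so they say nothing about the phenyl group on this side of the molecule. In this assay, the change from phenyl to 4-ethylphenyl brings a 5.0-fold lower number from compound 2 to compound 3 (0.70 log units; beyond the scatter) and is a modest step, but one that clears the usual scatter. It shows that, with cyclohexyl on the other carbonyl carbon, ethyl on this aromatic carbon, para to a large group, goes with an effect at smaller amounts of compound, and that this position can be changed without losing the effect; the data shown offer no explanation for this gain.

From the compounds shown here alone, whether ethyl would bring a similar step with the 2-methoxyphenyl of compound 1 in place of cyclohexyl remains open, and a single pair of compounds cannot establish a trend. Methyl, a longer chain such as butyl, or an amine at the same position could show whether the step follows the length of the chain or is particular to ethyl.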